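The source may report more compounds than this note shows. Statements on the series, on what has been measured and on what is new or still open speak of the compounds shown alone.

Two compounds with the same core and the same nitro group have been measured in a functional assay on U-373MG ATCC cells (Homo sapiens) for inhibition, read by MTT assay, with a stated time of 72 h; a higher number here means a weaker inhibitor, a lower number a stronger inhibitor. In it, compound 2 `CC1(C)CC(NC(=S)Nc2ccc([N+](=O)[O-])cc2)c2cc(Br)ccc2O1` gives 9000 nM and compound 3 `CC1(C)CC(NC(=S)Nc2ccc([N+](=O)[O-])cc2)c2cc(Cl)ccc2O1` gives 3000 nM. Compound 3 has the lowest of the three numbers available, with the third coming from compound 1 `CC1(C)CC(NC(=S)Nc2ccc(C#N)cc2)c2cc(F)ccc2O1`, which gives 11000 nM. Compound 4 `CC1(C)CC(NC(=S)Nc2ccc([N+](=O)[O-])cc2)c2cc(F)ccc2O1` differs from compound 3 at one place: fluoro in place of chloro on an aromatic carbon.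

Among the measured compounds shown here, the one measured step at this place is a 3.0-fold lower number from compound 2 to compound 3 (0.48 log units; beyond the scatter), a modest change that came with chloro in place of bromo. A single step sets no trend. Compound 1 already carries fluoro, but it has a nitrile instead of the nitro group, so it is only a loose guide, and its number of 11000 nM gives no sign of a low value. A small rise in this assay is therefore expected, no larger than the measured step and possibly within the scatter. The expected step is a 1.7-fold higher number from compound 3 to compound 4 (0.22 log units; within the scatter). Compound 4 is estimated at 5000 nM, with an expected range from 2000 nM to 13000 nM.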

Compound 4, half-maximal inhibitory concentration: 3000 nM
Beside the measured number, compound 4's estimate is 1.7-fold (0.22 log units) above it; the range from low to high includes it.
By their numbers in this assay, from the lowest: compounds 3 and 4 (each within the scatter of the next); then compounds 2 and 1 (each within the scatter of the next).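

With the nitro group held fixed, the halogen on this aromatic carbon now has three values in this assay: fluoro in place of chloro gives no change at the digits printed from compound 3 to compound 4 (within the scatter), whereas fluoro in place of bromo gives a 3.0-fold lower number from compound 2 to compound 4 (0.48 log units; beyond the scatter), so only the bromo compound stands apart among these three. Compound 4 also opens a comparison at a second place, since with fluoro held fixed, nitro in place of cyano gives a 3.7-fold lower number from compound 1 to compound 4 (0.56 log units; beyond the scatter). No evidence is available to explain either difference.

From the compounds shown here alone, it remains open how a hydrogen, a methyl group or an amine would behave on this aromatic carbon. Going by these compounds, it is also open whether chloro and fluoro would still match with a nitrile in place of the nitro group.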